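Swapping the Dichlorophenyl Arm for a Hydroxynaphthyl

A few compounds are considered here, and "the series" means these few. Any claim that something is new, unique, unknown or untested is made for them only; others in the source may bear on it.

Compound 3 `CN(C)CCn1cnnc1-c1cc(Oc2ccc(NC(=O)N/N=C/c3cccc(Cl)c3Cl)cc2F)ccn1` gives the lowest number of the three measured compounds in a functional assay on MKN-45 cells (Homo sapiens) for cytotoxicity, read by MTT assay, with a stated time of 72 h (on this read-out lower numbers stand for stronger inhibition and higher numbers for weaker inhibition), at 51 nM. Compound 1 `COc1ccc(/C=N/NC(=O)Nc2ccc(Oc3ccnc(-c4nncn4CCN(C)C)c3)c(F)c2)c(OC)c1` gives 1680 nM and compound 2 `COc1cc(/C=N/NC(=O)Nc2ccc(Oc3ccnc(-c4nncn4CCN(C)C)c3)c(F)c2)cc(OC)c1OC` gives 2900 nM in this assay. Going by the values given here, the only changes seen so far sit on the carbon with a double bond to nitrogen, and they are large: a 33-fold lower number from compound 1 to compound 3 (1.52 log units; beyond the scatter) and a 57-fold lower number from compound 2 to compound 3 (1.75 log units; beyond the scatter), while a 1.7-fold higher number from compound 1 to compound 2 (0.24 log units; within the scatter). Compound 4 `CN(C)CCn1cnnc1-c1cc(Oc2ccc(NC(=O)N/N=C/c3c(O)ccc4ccccc34)cc2F)ccn1` carries a different group at the same place: 2-hydroxynaphthalen-1-yl in place of 2,3-dichlorophenyl on a carbon with a double bond to nitrogen. Among the compounds with values here, no measured step shows this exact change, so the two steps into compound 3 are the only guide, and they show that the group on that carbon can move this assay strongly. Since compound 3 holds the lowest number and each other variation at this position gave a much higher one, a weakening is the more probable outcome, and the expected step is a 7.8-fold higher number from compound 3 to compound 4 (0.89 log units; beyond the scatter). Compound 4 is therefore estimated at 400 nM in this assay, with a range from 80 nM to 2500 nM, a wide span that reflects the absence of any close precedent for the entering group.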

Compound 4, half-maximal inhibitory concentration: 2020 nM
Beside the measured number, compound 4's estimate is 5.1-fold (0.70 log units) below it; the measured number falls inside the stated range.
By their numbers in this assay, from the lowest: compound 3; then compounds 1, 4 and 2 (each within the scatter of the next).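

The 2-hydroxynaphthalen-1-yl group on the carbon with a double bond to nitrogen brings a large change in this assay, with a 40-fold higher number from compound 3 to compound 4 (1.60 log units; beyond the scatter), so a second ring system and a hydrogen-bond donor do not restore what is lost when 2,3-dichlorophenyl leaves. Compound 4 also falls in with the two methoxy-bearing compounds, with a 1.4-fold lower number from compound 2 to compound 4 (0.16 log units; within the scatter) and a 1.2-fold higher number from compound 1 to compound 4 (0.08 log units; within the scatter), both within the scatter, so three quite different groups at this place give matching results and, among these four compounds, only the 2,3-dichlorophenyl group of compound 3 stands apart. Nothing in the available data gives a reason for this separation, and no measurement bears on it.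

The compounds shown leave open whether the low number of compound 3 depends on chlorine itself, on the pair of chlorine atoms, or on any unsubstituted-by-oxygen aryl group at this place. A 2,3-difluorophenyl, a 3-chlorophenyl, a 2,3-dimethylphenyl or a naphthalen-1-yl without the hydroxy group would separate these readings, and whether the hydroxy group or the second ring matters in compound 4 also remains unresolved.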